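Extending the Propyl Chain of Compound 3 to Pentyl

The compounds below may be only part of what the source reports. "The series", "measured", "known", "first", "only" and "open" are said of these compounds alone.

Within the data shown here, in a functional assay on the whole organism with Scenedesmus acutus as the target, with a stated time of 20 h (on this read-out higher numbers stand for weaker inhibition and lower numbers for stronger inhibition), compound 3 (`CCCOC(=O)c1cc(N2C(=O)C3=C(CCCC3)C2=O)ccc1Cl`) gives 661 nM, the highest of the three numbers measured so far. Compound 1 (`COC(=O)c1cc(N2C(=O)C3=C(CCCC3)C2=O)c(F)cc1Cl`) gives 170 nM, and compound 2 (`CCCOC(=O)c1cc(N2C(=O)C3=C(CCCC3)C2=O)c(F)cc1Cl`) gives 66.1 nM. Compound 4 (`CCCCCOC(=O)c1cc(N2C(=O)C3=C(CCCC3)C2=O)ccc1Cl`) differs from compound 3 by ethyl in place of hydrogen on a saturated chain carbon, three bonds along the chain from an oxygen next to a carbonyl group. This is ethyl in place of hydrogen on a saturated chain carbon, three bonds along the chain from an oxygen next to a carbonyl group, and it takes propyl to pentyl.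

Among the measured compounds shown here, the closest precedent is a 2.6-fold lower number from compound 1 to compound 2 (0.41 log units; beyond the scatter). That step also puts ethyl in place of hydrogen, but on the saturated chain carbon bound to the oxygen, and in compounds that carry the fluoro missing from compound 3. The other measured step, a 10-fold higher number from compound 2 to compound 3 (1.00 log units; beyond the scatter), exchanges fluoro for hydrogen and leaves the chain untouched. It bears on the new step only by showing that compound 3 sits in a different setting, where no chain change has yet been measured.

A smaller step in the same direction is therefore expected, and it may not clear the usual scatter. The estimate is a 1.7-fold lower number from compound 3 to compound 4 (0.22 log units; within the scatter). Compound 4 is expected at 400 nM, within an estimated range of 150 nM to 1100 nM.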

Compound 4, half-maximal inhibitory concentration: 5370 nM
For compound 4 the middle estimate is 13-fold (1.13 log units) below the measured one; the whole stated range lies below it.
By their numbers in this assay, from the lowest: compound 2; then compound 1; then compound 3; then compound 4.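

In this assay, taking propyl to pentyl weakens inhibition, with an 8.1-fold higher number from compound 3 to compound 4 (0.91 log units; beyond the scatter), so adding ethyl to this chain does not lower the number in every setting. Among these compounds, until now the only such change on record had pointed towards stronger inhibition, and the two steps now run in opposite directions, with a gap between them that exceeds what repeated measurements would produce: the same change on two cores in this assay, a 2.6-fold lower number (0.41 log units; beyond the scatter) from compound 1 to compound 2 and an 8.1-fold higher number (0.91 log units; beyond the scatter) from compound 3 to compound 4, 21-fold (1.32 log units) apart, beyond the scatter of two such steps. The outcome of the change therefore depends on its setting, and the two pairs differ in two ways, since compound 1 and compound 2 carry the fluoro that compound 3 and compound 4 lack, and their chains start from methyl rather than propyl.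

The compounds shown leave open which of these two differences matters, and a pentyl chain on the core of compound 2 would separate them by showing whether the fluoro keeps the longer chain favourable. They also leave open how the number climbs between propyl and pentyl on the core of compound 3, which a butyl chain would address, and whether a longer chain such as hexyl would weaken inhibition further.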